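A Chloro-to-Hydrogen Change Made on Two Different Cores

The compounds below may be only part of what the source reports. "The series", "measured", "known", "first", "only" and "open" are said of these compounds alone.

Two pairs of compounds carry the same change, made on two cores. Compound 1 `COc1cc(N(Cc2ccc(Cl)cc2)S(=O)(=O)c2ccc(C)cc2)cc(OC)c1OC` and compound 2 `COc1cc(N(Cc2ccccc2)S(=O)(=O)c2ccc(C)cc2)cc(OC)c1OC` form the first pair; compound 3 `Cc1ccc(S(=O)(=O)N(Cc2nc3ccccc3[nH]2)c2ccc(Cl)cc2)cc1` and the unmeasured compound 4 `Cc1ccc(S(=O)(=O)N(Cc2nc3ccccc3[nH]2)c2ccccc2)cc1` form the second. In a functional assay on MCF7 cells (Homo sapiens) for inhibition, read by MTT assay, with a stated time of 48 h (on this read-out lower numbers stand for stronger inhibition and higher numbers for weaker inhibition), compound 1 gives 18600 nM, and compound 2 gives 10200 nM. The difference between them is hydrogen in place of chloro on an aromatic carbon, and it brought a 1.8-fold lower number from compound 1 to compound 2 (0.26 log units; within the scatter). In this assay compound 3 gives 38300 nM, the highest of the three numbers and beyond the scatter from both compound 1 and compound 2. How the core of compound 3 differs from the core of compound 1 is not broken down here. The difference from compound 3 to compound 4 is hydrogen in place of chloro on an aromatic carbon; its place reads the same as in the first pair, so this is the same kind of change on another core. A similar small step is expected for compound 4 in this assay because the first pair gave a 1.8-fold lower number from compound 1 to compound 2 (0.26 log units; within the scatter). The expected step for compound 4 is a 1.7-fold lower number from compound 3 to compound 4 (0.24 log units; within the scatter). Compound 4 is estimated at 22000 nM, between 11000 nM and 45000 nM.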

Compound 4, half-maximal inhibitory concentration: 49700 nM
Beside the measured number, compound 4's estimate is 2.3-fold (0.35 log units) below it, outside the stated range (above it).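

In this assay, hydrogen in place of chloro on the second core gave a 1.3-fold higher number from compound 3 to compound 4 (0.11 log units; within the scatter). Set beside the first pair, the two steps cannot be told apart: the same change on two cores in this assay, a 1.8-fold lower number (0.26 log units; within the scatter) from compound 1 to compound 2 and a 1.3-fold higher number (0.11 log units; within the scatter) from compound 3 to compound 4, 2.4-fold (0.37 log units) apart, within the scatter of two such steps. The change therefore stays within the scatter on both cores and gives no sign that the core alters its outcome, but steps this small do not show that the two cores respond alike, and they say nothing about a change that would give a larger step.

The compounds shown leave open whether another group at the same place, such as fluoro, methoxy or an amine, would give a step beyond the scatter on either core. They also leave open which part of the difference between the core of compound 1 and the core of compound 3 goes with the gap in their values.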